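A few compounds are considered here, and "the series" means these few. Any claim that something is new, unique, unknown or untested is made for them only; others in the source may bear on it.

Compound 1 `CON=C1CCC(CN2CCN(c3nc(=O)c4cc(C(F)(F)F)cc([N+](=O)[O-])c4s3)C[C@H]2C)CC1` and compound 2 `CCON=C1CCC(CN2CCN(c3nc(=O)c4cc(C(F)(F)F)cc([N+](=O)[O-])c4s3)C[C@H]2C)CC1` share one core and differ only by methyl in place of hydrogen on a saturated chain carbon bound to an oxygen on an unsaturated carbon. In an ADME assay on Vero cells (Chlorocebus sabaeus) for cytotoxicity (on this read-out lower numbers stand for higher toxicity in this test and higher numbers for lower toxicity in this test), compound 1 reaches only the limit of the test, > 64 ug/mL. In this assay compound 2 likewise gives only a limit, > 64 ug/mL. The step that the two limits leave unreadable from compound 1 to compound 2 therefore cannot be read, because both values sit at the limit of > 64 ug/mL in this assay, at which 3 of the 3 values shown sit. Compound 3 `CON=C1CCC(CN2C(C)CN(c3nc(=O)c4cc(C(F)(F)F)cc([N+](=O)[O-])c4s3)CC2C)CC1` carries a core whose difference from that of compound 1 is not broken down here. In this assay compound 3 also gives only a limit, > 64 ug/mL. Compound 4 `CCON=C1CCC(CN2C(C)CN(c3nc(=O)c4cc(C(F)(F)F)cc([N+](=O)[O-])c4s3)CC2C)CC1` stands to compound 3 as compound 2 stands to compound 1, through the same change, (methyl in place of hydrogen on a saturated chain carbon bound to an oxygen on an unsaturated carbon), at the same place. With every measured value resting at the limit of > 64 ug/mL in this assay, at which 3 of the 3 values shown sit, no readable step exists to build on, and nothing in these three results suggests that this change brings toxicity into view. Compound 4 is therefore expected to give about 70 ug/mL, most probably once more only a limit. The change is estimated to amount to a step that the limit leaves unreadable from compound 3 to compound 4.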

Compound 4, half-maximal cytotoxic concentration: 60.5 ug/mL
Compound 4: middle estimate off by 1.2-fold (0.06 log units), on the high side, within the range that was stated.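

In this assay, the change from methoxy to ethoxy on the core of compound 3 gives an at least 1.0-fold lower number from compound 3 to compound 4 (0.02 log units; that floor lies within the scatter), and the floor of that step lies within the usual scatter of repeated measurements. Going by these compounds alone, on the core of compound 1 the same change cannot be read, because both of its ends rest on a limit: the limit of > 64 ug/mL in this assay, at which 3 of the 4 values shown sit. Taken together, the two pairs show only that the ethoxy compound on the second core gives a measured number, and they do not show that the change lowers the number on either core, or that it acts alike or differently on the two.

On these data alone, it remains open how this assay would read if a longer chain such as propoxy, or a chain ending in an amine, stood in place of the ethoxy group on either core. As far as these compounds go, it also remains open whether such a group would give a step that lies clearly beyond the scatter.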